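The source may report more compounds than this note shows. Statements on the series, on what has been measured and on what is new or still open speak of the compounds shown alone.

Measured compounds:
compound 1 `CC1(C)C=C(n2ccccc2=O)c2cc(C(=O)c3ccccc3)ccc2O1`, in a functional assay (trachea) with Rattus norvegicus as the target (a higher number here means a more potent compound, by a factor of ten per unit of this negative logarithm, a lower number a less potent compound), compound 1 gives 6.21
compound 2 `CC1(C)C=C(n2ccccc2=O)c2cc(C(=O)c3ccccc3[N+](=O)[O-])ccc2O1`, compound 2 gives 5.64
compound 3 `CC1(C)C=C(n2ccccc2=O)c2cc(C(=O)c3c(F)cccc3F)ccc2O1`, compound 3 gives 5.99

Compound 1 holds the highest of the three numbers; the gap to compound 3, a number 0.22 log units lower from compound 1 to compound 3 (within the scatter), is within the scatter, while compound 2 lies further off, a number 0.57 log units lower from compound 1 to compound 2 (beyond the scatter). Compound 4 `Cc1ccc(C)n1-c1ccc2c(c1)C(n1ccccc1=O)=CC(C)(C)O2` differs from compound 1 by 2,5-dimethyl-1H-pyrrol-1-yl in place of benzoyl on an aromatic carbon. Among the measured compounds shown here, none of the measured steps bears on this change: all three (a number 0.57 log units lower from compound 1 to compound 2 (beyond the scatter), a number 0.22 log units lower from compound 1 to compound 3 (within the scatter), a number 0.35 log units higher from compound 2 to compound 3 (beyond the scatter)) keep the benzoyl and alter only what sits on its ring, and all stay modest. For the measured compounds named here, replacing the benzoyl altogether has no precedent here, so the expectation is loose. The expected step is a modest drop, a number 0.51 log units lower from compound 1 to compound 4 (beyond the scatter). Compound 4 is estimated at 5.7, with an expected range of 5 to 6.4.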

Compound 4, logarithm of the reciprocal of the active concentration, log(1/C): 6.78
Compound 4: middle estimate off by 1.08 log units, on the low side; the whole stated range lies below it.
By their numbers in this assay, from the lowest: compound 2; then compounds 3 and 1 (each within the scatter of the next); then compound 4.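

In this assay, the benzoyl is not required at this aromatic carbon: a number 0.57 log units higher from compound 1 to compound 4 (beyond the scatter) on exchange for 2,5-dimethyl-1H-pyrrol-1-yl. The earlier steps shown here only altered the ring of the benzoyl, whereas this one shows that the whole group, carbonyl included, can give way to a five-membered aromatic ring with a hetero atom. Nothing measured here accounts for the gain.

From the compounds shown here alone, it remains open whether the methyl groups of the 2,5-dimethyl-1H-pyrrol-1-yl contribute. A plain 1H-pyrrol-1-yl or an amine such as morpholine at this carbon would address how far the position extends.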